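The source may hold more compounds than are shown below. What is called first, only, known or untested is meant among the compounds shown, and "the series" means these compounds.

In an ADME assay on cells (Homo sapiens) for cytotoxicity, read by resazurin assay, with a stated time of 5 days (on this read-out lower numbers stand for higher toxicity in this test and higher numbers for lower toxicity in this test), compound 1 `COc1ccc(-c2nc(CC(=O)c3cccc(Cl)c3)nc3ccsc23)cn1` gives 30000 nM. Compound 2 `COc1ccc(-c2nc(CSc3cc(C)cc(C)c3)nc3ccsc23)cn1` is reported only as a limit of the assay, > 50000 nM. Compound 3 `COc1ccc(-c2nc(CSc3cccc(Br)c3)nc3ccsc23)cn1` has 3-bromophenyl in place of 3,5-dimethylphenyl on a sulfur. Among the measured compounds shown here, only one measured step bears on this change, and only indirectly, since it replaces a different group: an at least 1.6-fold higher number from compound 1 to compound 2 (0.22 log units; that floor lies within the scatter). For the measured compounds named here, with that step as the only guide, no change beyond the scatter is expected in this assay. The estimated step is an at least 1.2-fold lower number from compound 2 to compound 3 (0.09 log units; that floor lies within the scatter). For compound 3 the expected value is 40000 nM, with an estimated range of 18000 nM to 60000 nM.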

Compound 3, half-maximal cytotoxic concentration: > 50000 nM
Compound 3 was reported as a limit; the forecaster's own chance of this, stated with the estimate: 55%; middle value at least 1.2-fold (0.09 log units) from the limit.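

In this assay compound 3 is reported only as a limit, as compound 2 is, so the step between them cannot be read, and a bromine-bearing phenyl on the sulfur ends at the same limit as the dimethylphenyl: the limit of > 50000 nM in this assay, at which 2 of the 3 values shown sit.

Putting (3-bromophenyl)sulfanyl in place of (3-chlorophenyl)carbonyl gives an at least 1.6-fold higher number from compound 1 to compound 3 (0.22 log units; that floor lies within the scatter), so this comparison establishes no change beyond the scatter.

From the compounds shown here alone, it remains open whether an amine or a carboxylic acid on the phenyl, or a longer chain carrying the sulfur, would give a measurable value in this assay rather than a limit.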